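This account rests on a few compounds, and the source may have more. Where it says the series, first, only, none or still open, it means among the compounds named here.

- compound 1 `COc1cc(OC)c(/C=C/S(=O)(=O)Cc2ccc(OC)c(NC(F)(F)C(=O)O)c2)c(OC)c1`: 150 nM
- compound 2 `COc1cc(OC)c(/C=C/S(=O)(=O)Cc2ccc(OC)c(NC(C(=O)O)c3ccc(F)cc3)c2)c(OC)c1`: 150 nM

Going by the values given here, in a functional assay on DU-145 cells (Homo sapiens) for cytotoxicity, read by trypan blue exclusion, with a stated time of 96 h (on this read-out lower numbers stand for stronger inhibition and higher numbers for weaker inhibition), compound 2 gives 150 nM, level with compound 1, the only compound it can be compared with so far. Compound 3 `COc1ccc(C(Nc2cc(CS(=O)(=O)/C=C/c3c(OC)cc(OC)cc3OC)ccc2OC)C(=O)O)cc1` has methoxy in place of fluoro on an aromatic carbon, para to a large group: methoxy in place of fluoro on an aromatic carbon. Among the compounds with values here, no measured step touches this position directly, so the evidence is indirect. Within the data shown here, the one step available is no change at the digits printed from compound 1 to compound 2 (within the scatter), in which carboxy(4-fluorophenyl)methyl took the place of carboxy(difluoro)methyl on a nitrogen on an aromatic ring. Swapping that whole group left the value unmoved, so a smaller edit within it is expected to do little, though a single step is thin support. The expected change, within the scatter and in neither direction, is no change at the digits printed from compound 2 to compound 3 (within the scatter). For compound 3 the estimated value is 150 nM, with an expected range of 50 nM to 450 nM.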

Compound 3, half-maximal inhibitory concentration: 100 nM
For compound 3 the middle estimate is 1.5-fold (0.18 log units) above the measured one, and the stated range covers the measured number.
By their numbers in this assay, from the lowest: compounds 3, 1 and 2 (each within the scatter of the next).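

In this assay, going by these compounds alone, methoxy in place of fluoro on an aromatic carbon, para to a large group, gives a 1.5-fold lower number from compound 2 to compound 3 (0.18 log units; within the scatter), the first direct reading at this position: these two groups cannot be told apart here. The wider replacement, of the whole group carrying the carboxylic acid, gives a 1.5-fold lower number from compound 1 to compound 3 (0.18 log units; within the scatter), so this exchange also stays inside the usual variation between repeat measurements. No other measurement is available that could explain these values.

From the compounds shown here alone, whether a different group on this aromatic carbon, such as an amine or a longer chain like butoxy, would move the value beyond the scatter remains open. Going by these compounds, all three compounds also carry a carboxylic acid, so the effect of an amide in its place is unknown.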